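The source may hold more compounds than are shown below. What is called first, only, known or untested is meant among the compounds shown, and "the series" means these compounds.

Working notes on the series. Of the compounds shown here, three built on one shared core have been measured in a functional assay on CCRF-CEM cells (Homo sapiens) for inhibition, read by cell counting, with a stated time of 3 days; a lower number here means a stronger inhibitor, a higher number a weaker inhibitor. Compound 1 `C=C(Br)C(=O)Nc1cccc(-c2cn3nc(-c4ccc(OC)c(OC)c4)sc3n2)c1` gives 380 nM. Compound 2 `C=C(Br)C(=O)Nc1cccc(-c2cn3nc(-c4ccc(OCC)cc4)sc3n2)c1` gives 1400 nM. Compound 3 `C=C(Br)C(=O)Nc1cccc(-c2cn3nc(-c4ccc(Cl)cc4)sc3n2)c1` gives 3200 nM and stands highest of the three numbers, with compound 2 nearest and compound 1 furthest from it. The measured steps all run the same way: a 3.7-fold higher number from compound 1 to compound 2 (0.57 log units; beyond the scatter), an 8.4-fold higher number from compound 1 to compound 3 (0.93 log units; beyond the scatter) and a 2.3-fold higher number from compound 2 to compound 3 (0.36 log units; beyond the scatter), each beyond the scatter.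

Compound 4 `C=C(Br)C(=O)Nc1cccc(-c2cn3nc(-c4ccccc4)sc3n2)c1` is the next member, still unmeasured. hydrogen in place of chloro on an aromatic carbon The change sits on an aromatic carbon of the six-membered aromatic ring of carbon only, para to a large group; cut one bond further out it reads 4-chlorophenyl to phenyl. For the measured compounds named here, the only measured step at this carbon is a 2.3-fold higher number from compound 2 to compound 3 (0.36 log units; beyond the scatter), which was modest. Going by the values given here, no measured step removes a substituent there altogether, so the direction for compound 4 is not fixed by the data. With the series moving to weaker inhibition as the substituent changes, a further small upward step is expected, a 1.4-fold higher number from compound 3 to compound 4 (0.15 log units; within the scatter), of a size near the scatter. Compound 4 is therefore estimated at 4500 nM, with a range from 1500 nM to 12000 nM, pending this assay.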

Compound 4, half-maximal inhibitory concentration: 960 nM
For compound 4 the middle estimate is 4.7-fold (0.67 log units) above the measured one, and the stated range ends above it.
By their numbers in this assay, from the lowest: compound 1; then compounds 4 and 2 (each within the scatter of the next); then compound 3.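

Taking the chloro off the 4-chlorophenyl gives a stronger inhibitor in this assay (a 3.3-fold lower number from compound 3 to compound 4 (0.52 log units; beyond the scatter)), so the rise in the number seen from compound 1 through compound 2 to compound 3 does not continue when this carbon carries only hydrogen, and chloro here goes with weaker inhibition than no substituent at all. Hydrogen in place of ethoxy gives no separation (a 1.5-fold lower number from compound 2 to compound 4 (0.16 log units; within the scatter)), so compound 2 and compound 4 cannot be ordered, while phenyl in place of 3,4-dimethoxyphenyl still costs activity (a 2.5-fold higher number from compound 1 to compound 4 (0.40 log units; beyond the scatter)), which leaves compound 1 the strongest inhibitor of the four and compound 3 the weakest. No measurement at hand accounts for any of these differences.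

Still open, from the compounds shown here alone, is whether a single methoxy on this ring would keep the activity of compound 1, or whether both methoxy groups are needed to hold it. Also open, going by these compounds, is how fluoro or bromo on this carbon would compare with chloro and hydrogen, and how an amine or a carboxylic acid there would read in this assay.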